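The source may hold more compounds than are shown below. What is called first, only, known or untested is meant among the compounds shown, and "the series" means these compounds.

Three compounds of this series carry a shared core with a sulfonyl group, and they differ only in the saturated chain and ring attached to the sulfonyl sulfur. Compound 1 `O=S(=O)(/C=C/c1ccc(O)c(O)c1)CC1CCC1` gives 8800 nM in a functional assay, read by fluorescence and spectrophotometry, with a stated time of 1 h; a lower number here means that less compound is needed, a higher number that more compound is needed for the effect. Among the measured compounds shown here, compound 3 `O=S(=O)(/C=C/c1ccc(O)c(O)c1)CC1CCCC1` gives 9400 nM in this assay, and the single step between them, a 1.1-fold higher number from compound 1 to compound 3 (0.03 log units; within the scatter), shows that a change of ring size on that carbon leaves the number where it was. Compound 2 `O=S(=O)(/C=C/c1ccc(O)c(O)c1)CCCc1ccccc1` gives 11500 nM in this assay; its value lies closest to that of compound 3 and farthest from that of compound 1, and neither gap reaches beyond the scatter.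

Compound 4 `O=S(=O)(/C=C/c1ccc(O)c(O)c1)CCCC1CCCCC1` has not yet been measured. Set against compound 2, the change is cyclohexyl in place of phenyl on a saturated chain carbon, three bonds along the chain from a sulfonyl sulfur. For the measured compounds named here, no measured pair swaps an aromatic ring for a saturated one, so the only step that bears on this one is the flat step from compound 1 to compound 3, where a saturated ring was exchanged for another saturated ring without effect. The three measured values sit close together, so the expected step is a 1.2-fold lower number from compound 2 to compound 4 (0.06 log units; within the scatter), not beyond the scatter. Compound 4 is therefore estimated to give 10000 nM, with a range from 5000 nM to 22000 nM.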

Compound 4, half-maximal effective concentration: 7900 nM
For compound 4 the middle estimate is 1.3-fold (0.10 log units) above the measured one, and the stated range covers the measured number.
By their numbers in this assay, from the lowest: compounds 4, 1, 3 and 2 (each within the scatter of the next).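

In this assay, the exchange of cyclohexyl for phenyl on a saturated chain carbon, three bonds along the chain from a sulfonyl sulfur, gives a 1.5-fold lower number from compound 2 to compound 4 (0.16 log units; within the scatter). Among the compounds shown here, the earlier step compared only one saturated ring with another, whereas this pair shows that, at this place and in this assay, an aromatic ring of six carbons and a non-aromatic ring of six carbons cannot be told apart beyond the scatter. The compounds shown offer no independent measurement that could account for this result.

Going by these compounds, all four compounds carry only carbon in the chain and ring on the sulfonyl sulfur, so it remains open whether an amine or a carboxylic acid at the end of the chain would move the number beyond the scatter. Also open, on these data alone, are a longer chain bearing the cyclohexyl ring and a plain open chain with no ring at all, either of which would show whether any change on this side of the shared core can shift the number in this assay.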